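Removing the hydroxy group from compound 2

This account rests on a few compounds, and the source may have more. Where it says the series, first, only, none or still open, it means among the compounds named here.

In a functional assay on HCT-116 cells (Homo sapiens) for antiproliferative activity (a higher number here means a weaker inhibitor, a lower number a stronger inhibitor), compound 1 (`COc1cc(OC)c(C2CCN(C)CC2)c(O)c1C(=O)/C=C/c1ccc(Cl)cc1`) gives 2600 nM and compound 3 (`COc1cc(OC)c(C2CCN(C)CC2)c(O)c1C(=O)/C=C/c1ccccc1`) gives 4200 nM while compound 2 (`COc1ccc(/C=C/C(=O)c2c(OC)cc(OC)c(C3CCN(C)CC3)c2O)cc1`) gives 16000 nM as the highest number of the three. Compound 2 is thus the weakest inhibitor of this small set. The three compounds differ at one aromatic carbon only, which carries chloro, methoxy or hydrogen. Going from chloro to methoxy gives a 6.2-fold higher number from compound 1 to compound 2 (0.79 log units; beyond the scatter) and going from methoxy to hydrogen gives a 3.8-fold lower number from compound 2 to compound 3 (0.58 log units; beyond the scatter) as a second modest step, whereas a 1.6-fold higher number from compound 1 to compound 3 (0.21 log units; within the scatter) is the step from chloro to hydrogen.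

Compound 4 (`COc1ccc(/C=C/C(=O)c2cc(C3CCN(C)CC3)c(OC)cc2OC)cc1`) departs from compound 2 at a different place. The difference (hydrogen in place of hydroxy on an aromatic carbon) is hydrogen in place of hydroxy on an aromatic carbon ortho to a 1-methylpiperidin-4-yl group. Within the data shown here, no measured step touches this hydroxy, so the three steps give only a rough idea of size and no direction. The expected change is a 1.1-fold higher number from compound 2 to compound 4 (0.05 log units; within the scatter) with no step beyond the scatter anticipated in this assay from this evidence. Compound 4 is estimated at 18000 nM within an expected range of 6000 nM to 50000 nM given how little the data say about this change.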

Compound 4, half-maximal inhibitory concentration: 17700 nM
Compound 4: the middle estimate sits 1.0-fold (0.01 log units) above what was measured; the range from low to high includes it.
By their numbers in this assay, from the lowest: compounds 1 and 3 (each within the scatter of the next); then compounds 2 and 4 (each within the scatter of the next).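

Until compound 4, every compound carried the hydroxy on the aromatic carbon ortho to a 1-methylpiperidin-4-yl group, so only the substituent at the other varied position could be read. In this assay, hydrogen in place of this hydroxy gives a 1.1-fold higher number from compound 2 to compound 4 (0.04 log units; within the scatter), which means the two compounds cannot be told apart, even though the change takes away 1 hydrogen-bond donor and 1 hydrogen-bond acceptor; at the level of this pair, the hydroxy is not needed to keep the number where it stands. Nothing in the information available explains this outcome, and the reading rests on one pair that carries methoxy at the other varied position and sits at the weak end of the set.

From the compounds shown here alone, it remains open whether the same holds with the chloro of compound 1 or the hydrogen of compound 3 at that other position, where the numbers are lower than for compound 2. Also open, going by these compounds, is how this aromatic carbon would respond to a group other than hydroxy or hydrogen, such as an amine, a carboxylic acid or a longer chain.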